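Furan-to-pyridine swap on the shared core of compound 1

This account rests on a few compounds, and the source may have more. Where it says the series, first, only, none or still open, it means among the compounds named here.

Compound 1 `CCN(c1ccc(C#N)c(Cl)c1)c1cc(-c2ccco2)ccc1C` is one of two measured members of the series. In a functional assay on VCaP cells (Homo sapiens) for antiproliferative activity, read by CCK-8 assay, with a stated time of 6 days (a higher number here means a weaker inhibitor, a lower number a stronger inhibitor), compound 1 returns only the assay limit, > 30000 nM. Compound 2 `CCN(c1cccc(-n2ccnc2)c1)c1ccc(C#N)c(C(F)(F)F)c1` is the other measured member; in this assay compound 2 likewise gives only a limit, > 30000 nM. Both measured values therefore stand at the same place: the limit of > 30000 nM in this assay, at which 2 of the 2 values shown sit. Among the measured compounds shown here, no step between measured compounds is available, so nothing on the size or direction of any change in this assay can be read from the numbers so far.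

Compound 3 `CCN(c1ccc(C#N)c(Cl)c1)c1cc(-c2cccnc2)ccc1C` has not yet been measured. It differs from compound 1 in one place: pyridin-3-yl in place of furan-2-yl on an aromatic carbon. With both measured compounds sitting at the limit, the expected step is a number no higher from compound 1 to compound 3 (the limit leaves the size open), which means none beyond the usual scatter. Compound 3 is accordingly estimated at 30000 nM in this assay, with a range from 5000 nM to 100000 nM, and the result is expected most likely to be reported again only as a limit.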

Compound 3, half-maximal inhibitory concentration: 1270 nM
Compound 3: the middle estimate sits 24-fold (1.37 log units) above what was measured; measured number outside the range, below it.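

In this assay, pyridin-3-yl in place of furan-2-yl gives an at least 23-fold lower number from compound 1 to compound 3 (1.37 log units; beyond the scatter), so the group on this aromatic carbon, meta to a large group and para to a methyl group, has a strong bearing on the read-out. Compound 3 is the only compound shown with a number rather than a limit, which gives this core a measured reference point for further changes at this position. The step is a bound and not an exact size, since the value for compound 1 is a limit: the limit of > 30000 nM in this assay, at which 2 of the 3 values shown sit.

Going by these compounds, what remains open is whether the place of the ring nitrogen matters, which pyridin-2-yl and pyridin-4-yl at this position would test. A plain phenyl ring there would show whether any ring nitrogen is needed for the step.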